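The source may report more compounds than this note shows. Statements on the series, on what has been measured and on what is new or still open speak of the compounds shown alone.

Measured so far in an assay on HEK293 cells for displacement of a labelled ligand from NPC1-like intracellular cholesterol transporter 1 (Homo sapiens); a lower number here means a stronger inhibitor, a higher number a weaker inhibitor:
- compound 1 `CC(C)(C)c1ccc(C(=O)N2CCC3(CC2)C(=O)N(CC(=O)N2CCCCC2CCO)CN3c2ccccc2)cc1`: 6100 nM
- compound 2 `CC(C)(C)c1ccc(C(=O)N2CCC3(CC2)C(=O)N(CC(=O)NCCCN)CN3c2ccccc2)cc1`: 4200 nM
- compound 3 `CC1(C)CC(OC(=O)CN2CN(c3ccccc3)C3(CCN(C(=O)c4ccc(C(C)(C)C)cc4)CC3)C2=O)CC(C)(C)N1`: 1300 nM

Compound 3 gives the lowest number of the three, and both steps toward it lie beyond the scatter: a 4.7-fold lower number from compound 1 to compound 3 (0.67 log units; beyond the scatter) and a 3.2-fold lower number from compound 2 to compound 3 (0.51 log units; beyond the scatter). The step of a 1.5-fold lower number from compound 1 to compound 2 (0.16 log units; within the scatter) is within the scatter, so the two carbonyl substituents in compound 1 and compound 2 are not separated here.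

Compound 4 `CC(C)(C)c1ccc(C(=O)N2CCC3(CC2)C(=O)N(CC(=O)N2CCCC(O)C2)CN3c2ccccc2)cc1` is the next variation at the same carbonyl carbon: 3-hydroxypiperidin-1-yl in place of (2,2,6,6-tetramethylpiperidin-4-yl)oxy on a carbonyl carbon. It replaces the (2,2,6,6-tetramethylpiperidin-4-yl)oxy group of compound 3 with a piperidin-1-yl group, the same kind of substituent as in compound 1, now carrying a hydroxyl directly on the ring. The two steps that bear on it are a 4.7-fold lower number from compound 1 to compound 3 (0.67 log units; beyond the scatter) and a 3.2-fold lower number from compound 2 to compound 3 (0.51 log units; beyond the scatter), both modest and both pointing the other way. Compound 4 is therefore expected to move back toward the values of compound 1 and compound 2, with the step of a 3.5-fold higher number from compound 3 to compound 4 (0.54 log units; beyond the scatter) in this assay. For compound 4 the estimate in this assay is 4500 nM, with a range from 2000 nM to 10000 nM.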

Compound 4, half-maximal inhibitory concentration: 12200 nM
Compound 4: middle estimate off by 2.7-fold (0.43 log units), on the low side; measured number outside the range, above it.
By their numbers in this assay, from the lowest: compound 3; then compounds 2, 1 and 4 (each within the scatter of the next, the first and the last beyond it).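

In this assay, a 9.4-fold higher number from compound 3 to compound 4 (0.97 log units; beyond the scatter) is the largest step yet at this carbonyl carbon, so the gap between (2,2,6,6-tetramethylpiperidin-4-yl)oxy and a hydroxylated piperidin-1-yl group is wider than compound 1 alone showed. Among the compounds shown here, with a 2.9-fold higher number from compound 2 to compound 4 (0.46 log units; beyond the scatter), the substituents attached through nitrogen are now separated from one another for the first time, since (3-aminopropyl)amino and 3-hydroxypiperidin-1-yl lie beyond the scatter. By contrast, a 2.0-fold higher number from compound 1 to compound 4 (0.30 log units; within the scatter) does not separate 3-hydroxypiperidin-1-yl from 2-(2-hydroxyethyl)piperidin-1-yl. Nothing available here explains these differences.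

Still open, from the compounds shown here alone, is whether the lower number of compound 3 goes with the oxygen link or with the tetramethylpiperidine ring, which a (2,2,6,6-tetramethylpiperidin-4-yl)amino group would separate. An unsubstituted piperidin-1-yl group would show what the hydroxyl contributes in compound 4.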